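Amide chain extension from ethyl to propyl

The source may hold more compounds than are shown below. What is called first, only, known or untested is meant among the compounds shown, and "the series" means these compounds.

Measured in a functional assay (muscle tissue) with Rattus norvegicus as the target; a higher number here means that more compound is needed for the effect, a lower number that less compound is needed:
- compound 1 (`CNC(=O)C1=CC(C)(C)Oc2ccc([N+](=O)[O-])cc21`) 10.7 nM
- compound 2 (`CCNC(=O)C1=CC(C)(C)Oc2ccc([N+](=O)[O-])cc21`) 4.57 nM

Compound 2 holds the lower of the two numbers, at 4.57 nM. Compound 3 (`CCCNC(=O)C1=CC(C)(C)Oc2ccc([N+](=O)[O-])cc21`) differs from it as follows: methyl in place of hydrogen on a saturated chain carbon, two bonds along the chain from an amide-type nitrogen. Among the measured compounds shown here, one measured step bears on this, a 2.3-fold lower number from compound 1 to compound 2 (0.37 log units; beyond the scatter), which is the same replacement made on a saturated chain carbon bound to an amide-type nitrogen. A single modest step sets no trend, so only a small further move toward a lower number in this assay is expected, possibly within the scatter. The expected change is a 1.3-fold lower number from compound 2 to compound 3 (0.12 log units; within the scatter). Compound 3 is estimated at 3.5 nM, with an expected range of 1.3 nM to 10 nM.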

Compound 3, half-maximal effective concentration: 5.75 nM
Compound 3: middle estimate off by 1.6-fold (0.22 log units), on the low side; measured number inside the range.
By their numbers in this assay, from the lowest: compounds 2, 3 and 1 (each within the scatter of the next, the first and the last beyond it).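

In this assay the step from ethyl to propyl gives (a 1.3-fold higher number from compound 2 to compound 3 (0.10 log units; within the scatter)) and so does not carry on the earlier gain from methyl to ethyl: compound 2 and compound 3 cannot be told apart. Compound 3 also stays within the scatter of compound 1 (a 1.9-fold lower number from compound 1 to compound 3 (0.27 log units; within the scatter)), although compound 1 and compound 2 are separated, so any benefit of chain length at this position is small. No measurement here offers an explanation of this flat response.
On these data alone, whether a longer chain such as butyl keeps this level remains open. So does the effect of a branched isopropyl group or a chain ending in an amine at this position.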